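Removing a Methyl from the Ketone Side Chain

This account rests on a few compounds, and the source may have more. Where it says the series, first, only, none or still open, it means among the compounds named here.

Compound 3 `CCC(C)C(=O)c1c(O)cc(O)c2c1O[C@](C)(CCC=C(C)C)[C@@H](O)C2` carries a (sec-butyl)carbonyl group, and in a functional assay on HMEC-1 cells (Homo sapiens) for inhibition, read by crystal violet staining, with a stated time of 72 h (a lower number here means a stronger inhibitor, a higher number a weaker inhibitor), compound 3 gives 18400 nM. Compound 1 `CCC(C)C(=O)c1c(O)cc(O)c2c1OC(C)(CCC=C(C)C)CC2` has the same ketone side chain on a closely related core, and in this assay compound 1 gives 13300 nM. Compound 2 `CC(C)=CCCC1(C)CCc2c(O)cc(O)c(C(=O)C(C)C)c2O1` carries isopropylcarbonyl instead, and in this assay compound 2 gives 16500 nM. Compound 3 shows the largest of the three numbers, but all three lie within the usual scatter of one another, so none can be singled out as a stronger or weaker inhibitor.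

Compound 4 `CC(C)=CCC[C@@]1(C)Oc2c(c(O)cc(O)c2C(=O)C(C)C)C[C@@H]1O` differs from compound 3 by a single change: hydrogen in place of methyl on a saturated chain carbon, two bonds along the chain from a carbonyl carbon. For the measured compounds named here, the one measured step that bears on this change is a 1.2-fold higher number from compound 1 to compound 2 (0.09 log units; within the scatter), the same change made on the core of compound 1, and that step stayed within the scatter. A similarly small step, or none beyond the scatter, is therefore expected for compound 4, namely a 1.1-fold higher number from compound 3 to compound 4 (0.06 log units; within the scatter). Compound 4 is accordingly estimated at 21000 nM, with a range from 10000 nM to 44000 nM.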

Compound 4, half-maximal inhibitory concentration: 23400 nM
The estimate for compound 4 lay 1.1-fold (0.05 log units) below the measured number, within the range that was stated.
By their numbers in this assay, from the lowest: compounds 1, 2, 3 and 4 (each within the scatter of the next).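

The change from (sec-butyl)carbonyl to isopropylcarbonyl now has a second reading in this assay, with a 1.3-fold higher number from compound 3 to compound 4 (0.10 log units; within the scatter), so what is known about it no longer rests on the core of compound 1 alone. Read side by side, the two steps show the same small size on both cores: the same change on two cores in this assay, a 1.2-fold higher number (0.09 log units; within the scatter) from compound 1 to compound 2 and a 1.3-fold higher number (0.10 log units; within the scatter) from compound 3 to compound 4, 1.0-fold (0.01 log units) apart, within the scatter of two such steps

For these four compounds, then, sec-butyl and isopropyl at this position cannot be told apart in this assay, on either core.

The compounds shown carry only these two branched groups at this place, and every step between them stays within the scatter, so they do not show whether any change here can move the number further. On these data alone, whether a longer chain such as n-hexyl, or an amine on this saturated chain carbon, would give a step beyond the scatter remains open.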